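A few compounds are considered here, and "the series" means these few. Any claim that something is new, unique, unknown or untested is made for them only; others in the source may bear on it.

Compound 1 `Cc1ccc2oc(SCC(=O)Nc3ccc(-c4nc(-c5ccccc5)c(-c5ccccc5)n4C)cc3)nc2c1` gives 22.4 ug/mL in a functional assay on HT-29 cells (Homo sapiens) for cytotoxicity, read by MTT assay, with a stated time of 24 h; a lower number here means a stronger inhibitor, a higher number a weaker inhibitor.
Compound 2 `Cn1nnnc1SCC(=O)Nc1ccc(-c2nc(-c3ccccc3)c(-c3ccccc3)n2C)cc1` gives 1.6 ug/mL in this assay.
Compound 3 `CCN1CCN(CC(=O)Nc2ccc(-c3nc(-c4ccccc4)c(-c4ccccc4)n3C)cc2)CC1` gives 75 ug/mL in this assay.

Compound 3 stands at the highest of the three numbers, making it the weakest inhibitor measured. Its nearest neighbour is compound 1, with the step of a 3.3-fold higher number from compound 1 to compound 3 (0.52 log units; beyond the scatter); furthest away is compound 2, with the step of a 47-fold higher number from compound 2 to compound 3 (1.67 log units; beyond the scatter). The remaining step, a 14-fold lower number from compound 1 to compound 2 (1.15 log units; beyond the scatter), shows how strongly the two sulfur-bearing groups differ from each other.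

Compound 4 `CN(C)/C=C/N1CCN(CC(=O)Nc2ccc(-c3nc(-c4ccccc4)c(-c4ccccc4)n3C)cc2)CC1` keeps the shared core and the piperazine ring of compound 3 and changes only the group on the ring nitrogen: 2-(dimethylamino)ethenyl in place of ethyl on an amine nitrogen in a ring. Within the data shown here, none of the measured steps touches that position; each of them replaces the whole group on a saturated chain carbon bound to a carbonyl carbon. Among the measured compounds shown here, no measured step therefore bears directly on this change, and no step beyond the scatter is expected in this assay in either direction. Compound 4 is expected to give about 70 ug/mL, within a range from 28 ug/mL to 175 ug/mL, which means an expected step of a 1.1-fold lower number from compound 3 to compound 4 (0.03 log units; within the scatter).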

Compound 4, half-maximal inhibitory concentration: 80 ug/mL
For compound 4 the middle estimate is 1.1-fold (0.06 log units) below the measured one; the range from low to high includes it.
By their numbers in this assay, from the lowest: compound 2; then compound 1; then compounds 3 and 4 (each within the scatter of the next).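

In this assay, the step on the amine nitrogen in a ring is a 1.1-fold higher number from compound 3 to compound 4 (0.03 log units; within the scatter), so compound 3 and compound 4 cannot be told apart even though 2-(dimethylamino)ethenyl brings a double bond and a hydrogen-bond acceptor that ethyl lacks. The large gap to the tetrazole compound remains with this new group, at a 50-fold higher number from compound 2 to compound 4 (1.70 log units; beyond the scatter), and the gap to the benzoxazole compound is a 3.6-fold higher number from compound 1 to compound 4 (0.55 log units; beyond the scatter), so neither ring-nitrogen group comes near the sulfur-linked compounds. Nothing available explains why these two groups give results within the scatter.

Still open, going by these compounds, is whether a free amine hydrogen, an acetyl group or a longer chain ending in a carboxylic acid on this ring nitrogen would also stay within the scatter of compound 3. On these data alone, it is also open whether a different ring on the sulfur, such as a 1-methylimidazol-2-yl group, would fall nearer compound 2 or compound 1.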